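The source may report more compounds than this note shows. Statements on the series, on what has been measured and on what is new or still open speak of the compounds shown alone.

Working notes on the series. All four members share one core and differ only in the group on the amine nitrogen. Compound 1 `Cc1ccc(NC2=CC(=O)c3c(nc4n3[C@H]3OC[C@@H](O)[C@H]3OC4)C2=O)cc1` carries the 4-methylphenyl group; in a functional assay on MCF7 cells (Homo sapiens) for inhibition, read by sulforhodamine B assay (a higher number here means a weaker inhibitor, a lower number a stronger inhibitor), compound 1 gives > 4000 nM, which is a limit of the assay rather than a number (the limit of > 4000 nM in this assay, at which 1 of the 3 values shown sits). Compound 2 `O=C1C=C(Nc2ccc(Br)cc2)C(=O)c2c1nc1n2[C@H]2OC[C@@H](O)[C@H]2OC1` gives 2580 nM. Compound 3 `COc1ccc(NC2=CC(=O)c3nc4n(c3C2=O)[C@H]2OC[C@@H](O)[C@H]2OC4)cc1` gives 5420 nM; the step of a 2.1-fold higher number from compound 2 to compound 3 (0.32 log units; beyond the scatter) is modest. Compound 4 `O=C1C(NCc2ccccc2)=CC(=O)c2c1nc1n2[C@H]2OC[C@@H](O)[C@H]2OC1` differs from compound 1 by benzyl in place of 4-methylphenyl on an amine nitrogen. Going by the values given here, no measured step exchanges an aromatic group for a benzyl on the amine nitrogen, so the measured steps give no direct guide; all three measured members sit at weak inhibition, and the expectation is that compound 4 stays in that region, an estimated step that the limit leaves unreadable from compound 1 to compound 4 with no clear direction. Compound 4 is estimated at 5000 nM, with a range from 1800 nM to 15000 nM.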

Compound 4, half-maximal inhibitory concentration: > 8000 nM
Compound 4: only a limit was reported; the forecaster's own chance of this, stated with the estimate: 45%; at least 1.6-fold (0.20 log units) between middle value and limit.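

Going by these compounds alone, compound 1 and compound 4 are both reported only as limits of the assay, and no step between them can be read. As far as these compounds go, whether benzyl or 4-methylphenyl on the amine nitrogen gives the stronger inhibitor remains open.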